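A few compounds are considered here, and "the series" means these few. Any claim that something is new, unique, unknown or untested is made for them only; others in the source may bear on it.

Compound 1 `Cc1c(C(=O)N/N=C\c2cccc(F)c2)oc2cccc(O)c12` is the starting point. In a functional assay on PC-3 cells (Homo sapiens) for inhibition (a higher number here means a weaker inhibitor, a lower number a stronger inhibitor), compound 1 gives only a limit, >= 40000 nM, so its place among the numbers shown is fixed only by that limit. Compound 4 `Cc1c(C(=O)N/N=C\c2cccc(Br)c2O)oc2cccc(O)c12` differs from it in a single place: 3-bromo-2-hydroxyphenyl in place of 3-fluorophenyl on a carbon with a double bond to nitrogen. Going by the values given here, two measured steps bear on this change. Compound 2 `Cc1c(C(=O)N/N=C\c2cccc(O)c2O)oc2cccc(O)c12` gives 12200 nM in this assay, an at least 3.2-fold lower number from compound 1 to compound 2 (0.51 log units; beyond the scatter). Compound 3 `Cc1c(C(=O)N/N=C\c2cc(Cl)ccc2O)oc2cccc(O)c12` gives 3120 nM, an at least 12-fold lower number from compound 1 to compound 3 (1.10 log units; beyond the scatter); between these two there is a 3.9-fold lower number from compound 2 to compound 3 (0.59 log units; beyond the scatter). Since compound 3 also pairs a halogen with a hydroxyl on the phenyl, the step of an at least 12-fold lower number from compound 1 to compound 3 (1.10 log units; beyond the scatter) is the closer guide, and compound 4 is expected to show an at least 8.0-fold lower number from compound 1 to compound 4 (0.90 log units; beyond the scatter). Compound 4 is therefore estimated at 5000 nM in this assay, in the range 1500 nM to 20000 nM.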

Compound 4, half-maximal inhibitory concentration: 16600 nM
Estimate against measurement, compound 4: 3.3-fold (0.52 log units) below; low and high end bracket the measured number.
By their numbers in this assay, from the lowest: compound 3; then compounds 2 and 4 (each within the scatter of the next). At a limit, above all of these: compound 1.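

Compound 1 holds only a limit of the assay: the limit of >= 40000 nM in this assay, at which 1 of the 4 values shown sits.

Even so, in this assay the 3-bromo-2-hydroxyphenyl group retains a gain over 3-fluorophenyl, with an at least 2.4-fold lower number from compound 1 to compound 4 (0.38 log units; beyond the scatter), yet pairing a halogen with a hydroxyl does not alone match 5-chloro-2-hydroxyphenyl, with a 5.3-fold higher number from compound 3 to compound 4 (0.73 log units; beyond the scatter). Bromo in place of hydroxy gives a 1.4-fold higher number from compound 2 to compound 4 (0.13 log units; within the scatter), so compound 2 and compound 4 cannot be ordered.

The compounds shown leave open whether the halogen or its place accounts for the gap separating compound 3 and compound 4. On these data alone, how an amine or a carboxylic acid on the phenyl would behave also remains open.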